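The source may report more compounds than this note shows. Statements on the series, on what has been measured and on what is new or still open speak of the compounds shown alone.

Measured so far:
compound 1 `CNCCCNc1cc2c(cc1F)c(=O)c(C(=O)O)cn2Cc1ccc(-c2ccccc2)cc1` — 63600 nM
compound 2 `O=C(O)c1cn(Cc2ccc(-c3ccccc3)cc2)c2cc(NC[C@H]3CCNC3)c(F)cc2c1=O` — 100000 nM

In an assay on isolated protein for inhibition of DNA topoisomerase 1 (Homo sapiens), with a stated time of 15 min (on this read-out higher numbers stand for weaker inhibition and lower numbers for stronger inhibition), compound 1 gives 63600 nM and compound 2 gives 100000 nM. On paper the number for compound 2 is the larger of the two, but the gap is a 1.6-fold higher number from compound 1 to compound 2 (0.20 log units; within the scatter), within the scatter, so the two compounds are not separated by this read-out. Compound 3 `O=C(O)c1cn(Cc2ccc(-c3ccccc3)cc2)c2cc(NC[C@@H]3CCNC3)c(F)cc2c1=O` has not yet been run in this assay. Compared with compound 2: the two compounds have the same atoms and bonds and differ only in configuration as drawn: 1 of 1 stereo elements differ; a stereocentre at a saturated ring carbon is drawn S in compound 2 and R in compound 3. Within the data shown here, no measured step involves a change of configuration alone; the single known step, a 1.6-fold higher number from compound 1 to compound 2 (0.20 log units; within the scatter), swaps one amine-bearing side group for another and stays within the scatter, which gives no ground to expect the two configurations to separate. The expectation for compound 3 is therefore no change at the digits printed from compound 2 to compound 3 (within the scatter), nothing beyond the scatter. Compound 3 is estimated at 100000 nM, with a range of 40000 nM to 250000 nM.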

Compound 3, half-maximal inhibitory concentration: 104000 nM
Compound 3: the middle estimate sits 1.0-fold (0.02 log units) below what was measured, and the stated range covers the measured number.
By their numbers in this assay, from the lowest: compounds 1, 2 and 3 (each within the scatter of the next).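

In this assay, inverting the stereocentre gives a 1.0-fold higher number from compound 2 to compound 3 (0.02 log units; within the scatter), so this saturated ring carbon of the pyrrolidin-3-yl group tolerates either drawn configuration without a separation on this read-out. Earlier data held no reading of configuration alone, and this pair supplies one: the fact that compounds 2 and 3 differ only in the configuration as drawn. Placing the R form against the open-chain compound gives a 1.6-fold higher number from compound 1 to compound 3 (0.21 log units; within the scatter), so neither configuration of the pyrrolidin-3-yl group separates from the 2-(methylamino)ethyl group.

The compounds shown leave open whether configuration at this carbon would count with another amine at this place, such as a piperazine or a primary amine on a longer chain. They also leave open whether replacing the carboxylic acid with an amide would shift the numbers for the whole set.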